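The source may report more compounds than this note shows. Statements on the series, on what has been measured and on what is new or still open speak of the compounds shown alone.

Measured compounds:
compound 1, `COc1cc(-c2cc(/C=C/C(=O)c3ccc(N)cc3)[nH]n2)cc(OC)c1OC`, gives 102% in a functional assay on MOLT-4 cells (Homo sapiens) for cytotoxicity, read by sulforhodamine B assay, with a stated time of 48 h, tested at 0.1 uM; a lower number here means a stronger effect, a higher number a weaker effect of the compound at the concentration tested.
compound 2, `COc1ccc(-c2cc(/C=C/C(=O)c3ccc(OC)c(OC)c3)[nH]n2)cc1`, gives 108% in this assay.
compound 3, `COc1cc(-c2cc(/C=C/C(=O)c3ccc(Cl)c(Cl)c3)[nH]n2)cc(OC)c1OC`, gives 102% in this assay.

Compound 3 stands level with compound 1 at the digits shown, and the two are together the lowest of the three numbers; the gap between compound 2 and compound 3 is within the scatter, so no order among the three can be read. All three sit close to unchanged growth in this assay at the concentration tested.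

Compound 4, `COc1ccc(C(=O)/C=C/c2cc(-c3cc(OC)c(OC)c(OC)c3)n[nH]2)cc1OC`, is not yet measured. Its difference from compound 3 is 3,4-dimethoxyphenyl in place of 3,4-dichlorophenyl on a carbonyl carbon. For the measured compounds named here, the only measured step on the carbonyl-carbon substituent is no change at the digits printed from compound 1 to compound 3 (within the scatter), where the exchange of one aryl group for another left the number where it was. Going by the values given here, compound 2 also carries 3,4-dimethoxyphenyl on its carbonyl carbon, but its other ring differs from that of compound 3, so no single-change step connects them; its value and that of compound 3 lie within the scatter of each other. Against that background no step beyond the scatter is expected for compound 4, which means a change of a number 1 percentage points higher from compound 3 to compound 4 (within the scatter). The estimate for compound 4 is 103%, with a range from 92% to 114%.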

Compound 4, a percentage reported as activity, at one concentration (the size of the read-out at that concentration, not a potency): 98%
Beside the measured number, compound 4's estimate is 5 percentage points above it, within the range that was stated.
By their numbers in this assay, from the lowest: compounds 4, 1, 3 and 2 (each within the scatter of the next).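

Three aryl groups have now been compared on the carbonyl carbon of the same core, and the number has not moved beyond the scatter for any of them. In this assay, 3,4-dimethoxyphenyl in place of 3,4-dichlorophenyl gives a number 4 percentage points lower from compound 3 to compound 4 (within the scatter) as the step, and in place of 4-aminophenyl it gives a number 4 percentage points lower from compound 1 to compound 4 (within the scatter) as the step, so the earlier flat result at this position also holds for a group with hydrogen-bond acceptors that 3,4-dichlorophenyl lacks. No other data accompany these values to help interpret this flat result.

Since compound 1, compound 3 and compound 4 all sit close to unchanged growth at this one concentration, the series cannot yet separate a position that tolerates change from a core with little effect at this concentration, whichever aryl group it carries. From the compounds shown here alone, it remains open whether a carboxylic acid, a basic amine on a longer chain or a non-aromatic group on the carbonyl carbon would shift the number, and whether the three aryl groups would separate at a higher concentration.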